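The source may report more compounds than this note shows. Statements on the series, on what has been measured and on what is new or still open speak of the compounds shown alone.

Measured compounds:
- compound 1, `Nc1nc(O)c2c(n1)n(C1OC(CO)[C@@H](O)[C@H]1O)c(=O)n2CC(O)CSc1ccccc1`, gives 12% in a functional assay on the whole organism (B cells) with Mus musculus as the target; on this read-out higher numbers stand for larger maximal responses and lower numbers for smaller maximal responses
- compound 2, `Nc1nc(O)c2c(n1)n(C1OC(CO)[C@@H](O)[C@H]1O)c(=O)n2Cc1ccccc1`, gives 110%
- compound 3, `Nc1nc(O)c2c(n1)n(C1OC(CO)[C@@H](O)[C@H]1O)c(=O)n2C/C=C/c1ccccc1`, gives 73%

Compound 3 stands second highest of the three numbers in this assay. Its nearest neighbour is compound 2, a step of a number 37 percentage points lower from compound 2 to compound 3 (beyond the scatter); its furthest is compound 1, a step of a number 61 percentage points higher from compound 1 to compound 3 (beyond the scatter). All three compounds share the same core, and they differ only in the group on a saturated chain carbon bound to an aromatic nitrogen.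

Compound 4, `N#Cc1ccc(Cn2c(=O)n(C3OC(CO)[C@@H](O)[C@H]3O)c3nc(N)nc(O)c32)cc1`, is not yet measured. Its difference from compound 3 is 4-cyanophenyl in place of 2-phenylethenyl on a saturated chain carbon bound to an aromatic nitrogen.

Within the data shown here, no measured step swaps a 2-phenylethenyl for a 4-cyanophenyl, so the expectation rests on neighbouring steps. The step of a number 37 percentage points lower from compound 2 to compound 3 (beyond the scatter) shows that replacing phenyl by 2-phenylethenyl lowered the maximal response, so returning to a group built on a phenyl ring, now bearing a nitrile, is expected to move the number back up. Among the measured compounds shown here, the nitrile itself has no counterpart among the measured compounds, which widens the range.

For compound 4 in this assay the expected value is 95%, between 55% and 130%, which would mean an estimated step of a number 22 percentage points higher from compound 3 to compound 4 (beyond the scatter).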

Compound 4, largest response reached (reported as maximal response), in percent of the reference or control that the assay uses: 50%
For compound 4 the middle estimate is 45 percentage points above the measured one, outside the stated range (below it).
By their numbers in this assay, from the lowest: compound 1; then compound 4; then compound 3; then compound 2.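

In this assay, the cleanest reading comes from cyano in place of hydrogen on an aromatic carbon, a single change to the phenyl ring that gives a number 60 percentage points lower from compound 2 to compound 4 (beyond the scatter). A phenyl ring on this saturated chain carbon therefore does not guarantee a high response, and what the ring carries matters: 4-cyanophenyl in place of 2-phenylethenyl gives a number 23 percentage points lower from compound 3 to compound 4 (beyond the scatter), while 4-cyanophenyl in place of 1-hydroxy-2-(phenylsulfanyl)ethyl still gives a number 38 percentage points higher from compound 1 to compound 4 (beyond the scatter). Nothing available explains why the nitrile is linked to this lower response.

The compounds shown leave open whether this drop is specific to the nitrile or would follow any group replacing that ring hydrogen, a question that a chlorine atom, a methoxy group or an amine in place of the nitrile of compound 4 could address. They also leave open how much of the difference between the 4-cyanobenzyl and 3-phenylprop-2-en-1-yl groups depends on chain length, which a 2-phenylethyl group could help separate.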